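The compounds below may be only part of what the source reports. "The series", "measured", "known", "first", "only" and "open" are said of these compounds alone.

Working notes on the dithiocarbamate series. Compound 1 `S=C(SCc1nc2cc(Cl)c(Cl)cc2[nH]1)N1CCCCC1` gives 42800 nM in a functional assay on MCF7 cells (Homo sapiens) for cytotoxicity, read by MTT assay, with a stated time of 24 h; on this read-out lower numbers stand for stronger inhibition and higher numbers for weaker inhibition. Compound 2 `CN1CCN(C(=S)SCc2nc3cc(Cl)c(Cl)cc3[nH]2)CC1` gives 30500 nM, and the step from the first to the second is a 1.4-fold lower number from compound 1 to compound 2 (0.15 log units; within the scatter). Compound 3 `COc1ccc(N2CCN(C(=S)SCc3nc4cc(C)c(C)cc4[nH]3)CC2)cc1` gives 46000 nM, which sits at the upper end of the three numbers, though nothing separates compound 3 from compound 1 or compound 2 beyond the scatter.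

Compound 4 `Cc1cc2nc(CSC(=S)N3CCN(c4ccccc4Cl)CC3)[nH]c2cc1C` is not yet measured. It differs from compound 3 in one place: 2-chlorophenyl in place of 4-methoxyphenyl on an amine nitrogen in a ring. Among the measured compounds shown here, no measured step changes the group on the amine nitrogen in a ring; the one step known, from compound 1 to compound 2, changes the ring on the thiocarbonyl carbon and on a core with two chlorines, and it stayed within the scatter. For the measured compounds named here, every number so far lies within one band, so the step to compound 4 is expected to be a 1.2-fold lower number from compound 3 to compound 4 (0.06 log units; within the scatter), with no direction beyond the scatter. Compound 4 is therefore estimated at 40000 nM, in the range 15000 nM to 100000 nM.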

Compound 4, half-maximal inhibitory concentration: 8390 nM
For compound 4 the middle estimate is 4.8-fold (0.68 log units) above the measured one; measured number below the stated range.
By their numbers in this assay, from the lowest: compound 4; then compounds 2, 1 and 3 (each within the scatter of the next).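

In this assay the group on the amine nitrogen in a ring can move the number: 2-chlorophenyl in place of 4-methoxyphenyl gives a 5.5-fold lower number from compound 3 to compound 4 (0.74 log units; beyond the scatter) and is the only step shown that lies beyond the scatter. The earlier step of a 1.4-fold lower number from compound 1 to compound 2 (0.15 log units; within the scatter) on the thiocarbonyl carbon stayed within the scatter, so this amine nitrogen is the first place in the series shown to respond to a change. The reading rests on a single pair, on the shared core of compound 3 and compound 4.

Still open, going by these compounds, is whether the step belongs to the chlorine, its place on the phenyl ring or the loss of the methoxy group, which an unsubstituted phenyl, a 4-chlorophenyl or a 2-methoxyphenyl on this nitrogen would separate. No measurement at hand bears on the cause of this step.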